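Tert-butyl for Methoxy on the Phenoxy Group: Expected Dissociation

This account rests on a few compounds, and the source may have more. Where it says the series, first, only, none or still open, it means among the compounds named here.

Compound 1 `COc1ccc(Oc2ccc3c(NCCCNCc4cc(F)ccc4OC)ccnc3c2)cc1` was measured in a physicochemical assay for acid dissociation, where compound 1 gives 9.28. Compound 2 `c1ccc(Oc2ccc3c(NCCCNCc4ccco4)ccnc3c2)cc1` gives 9.28 in this assay, and compound 3 `COc1ccc(Oc2ccc3c(NCCCNCc4cccc(OC)c4O)ccnc3c2)cc1` gives 9.28, so compound 1 stands level with both at the recorded digits, within the scatter. Within the data shown here, the single step measured between neighbouring compounds, no change at the digits printed from compound 1 to compound 3 (within the scatter), exchanged the aromatic group on the saturated chain carbon bound to the amine nitrogen and produced no change within the scatter.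

Compound 4 `COc1ccc(F)cc1CNCCCNc1ccnc2cc(Oc3ccc(C(C)(C)C)cc3)ccc12` differs from compound 1 by tert-butyl in place of methoxy on an aromatic carbon; cut one bond further out, the difference reads 4-methoxyphenoxy to 4-(tert-butyl)phenoxy. Among the measured compounds shown here, no measured step touches this phenoxy group, so the expectation rests on the observation that the three measured compounds, altered elsewhere, all sit at the same value. Compound 4 is therefore expected to show no step beyond the scatter, no change at the digits printed from compound 1 to compound 4 (within the scatter). Compound 4 is estimated at 9.28, with a range from 8.95 to 9.6.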

Compound 4, acid dissociation constant: 9.28
Compound 4: the middle estimate sits on the measured number at the digits printed, and the stated range covers the measured number.
By their numbers in this assay, from the lowest: compounds 1, 2, 3 and 4 (each within the scatter of the next).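

Among these compounds, until now, the only measured step in this assay had exchanged the aromatic group on the saturated chain carbon, leaving the phenoxy group untouched. This result adds a reading at a second place in the molecule: on an aromatic carbon para to a large group, tert-butyl in place of methoxy gives no change at the digits printed from compound 1 to compound 4 (within the scatter) for the swap. Methoxy, with 2 heavy atoms and 1 hydrogen-bond acceptor, and tert-butyl, with 4 heavy atoms and 0 hydrogen-bond acceptors, are therefore not told apart at this position by this read-out, and no supporting measurement accounts for that.

From the compounds shown here alone, whether a carboxylic acid or an amine at this same position would also leave this assay unmoved remains open. So does the outcome for a longer chain on the amine nitrogen.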